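A few compounds are considered here, and "the series" means these few. Any claim that something is new, unique, unknown or untested is made for them only; others in the source may bear on it.

Among the measured compounds shown here, in a functional assay on A-375 cells (Homo sapiens) for antiproliferative activity (a higher number here means a weaker inhibitor, a lower number a stronger inhibitor), compound 1 `O=C(Nc1ccc(-c2cscn2)cc1)C1CCCN(Cc2ccc(F)c(F)c2)C1` gives 880 nM, the only exact number so far. Compound 2 `O=C(Nc1ccc(-c2cscn2)cc1)C1CCCN(Cc2cccnc2)C1` is reported as > 20000 nM, which is a limit of the assay. Compound 3 `O=C(Nc1ccc(-c2cccnc2)cc1)C1CCCN(Cc2ccc(F)c(F)c2)C1` has pyridin-3-yl in place of 1,3-thiazol-4-yl on an aromatic carbon. For the measured compounds named here, the only measured step, an at least 22-fold higher number from compound 1 to compound 2 (1.35 log units; beyond the scatter), brought pyridin-3-yl in place of 3,4-difluorophenyl elsewhere in the molecule, so it is a loose guide, and a smaller move toward weaker inhibition is expected here. The expected step is a 2.0-fold higher number from compound 1 to compound 3 (0.31 log units; beyond the scatter). Compound 3 is estimated at 1800 nM, with an expected range from 400 nM to 8000 nM.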

Compound 3, half-maximal inhibitory concentration: 610 nM
The estimate for compound 3 lay 3.0-fold (0.47 log units) above the measured number, within the range that was stated.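

In this assay, pyridin-3-yl in place of 1,3-thiazol-4-yl makes no change beyond the scatter (a 1.4-fold lower number from compound 1 to compound 3 (0.16 log units; within the scatter)), so this position on the aromatic ring accepts either ring. The same pyridin-3-yl has a much larger effect at the other end of the molecule (an at least 22-fold higher number from compound 1 to compound 2 (1.35 log units; beyond the scatter)), so its effect depends on where it sits. The data shown offer no explanation for this difference.

From the compounds shown here alone, it remains open whether this position also accepts a plain phenyl ring, or a non-ring group such as an amine or a carboxylic acid.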